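The source may hold more compounds than are shown below. What is called first, only, known or untested is meant among the compounds shown, and "the series" means these compounds.

Within the data shown here, the three compounds measured so far share one core and differ only in the amine at the end of a chain that sits three bonds along from an oxygen on an aromatic ring. In a functional assay on SK-BR-3 cells (Homo sapiens) for antiproliferative activity (a higher number here means a weaker inhibitor, a lower number a stronger inhibitor), compound 1 `CCN(CC)CCCOc1ccc2cc(NC(=O)c3ccc(O)c(CC=C(C)C)c3)c(=O)oc2c1C` gives 4900 nM. Compound 2 `CCCNCCCOc1ccc2cc(NC(=O)c3ccc(O)c(CC=C(C)C)c3)c(=O)oc2c1C` gives 990 nM in this assay. Compound 3 `CCCN(CCC)CCCOc1ccc2cc(NC(=O)c3ccc(O)c(CC=C(C)C)c3)c(=O)oc2c1C` gives only a limit in this assay, > 50000 nM. Compound 3 thus stands at the weak end of the three: an at least 50-fold higher number from compound 2 to compound 3 (1.70 log units; beyond the scatter), and an at least 10-fold higher number from compound 1 to compound 3 (1.00 log units; beyond the scatter).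

Compound 4 `CC(C)=CCc1cc(C(=O)Nc2cc3ccc(OCCCNCC(N)=O)c(C)c3oc2=O)ccc1O` has not been measured. It differs from compound 3 in one place: (carbamoylmethyl)amino in place of dipropylamino on a saturated chain carbon, three bonds along the chain from an oxygen on an aromatic ring. The step that bears most directly on this is an at least 50-fold higher number from compound 2 to compound 3 (1.70 log units; beyond the scatter), read in reverse, since a hydrogen on the amine nitrogen went with a far lower number; the smaller step of a 4.9-fold lower number from compound 1 to compound 2 (0.69 log units; beyond the scatter) points the same way. Compound 4 keeps a hydrogen on its amine nitrogen, so a large drop in this assay is expected: an at least 25-fold lower number from compound 3 to compound 4 (1.39 log units; beyond the scatter). Compound 4 is therefore estimated at 2000 nM, with a likely range from 500 nM to 15000 nM.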

Compound 4, half-maximal inhibitory concentration: 2290 nM
Beside the measured number, compound 4's estimate is 1.1-fold (0.06 log units) below it, within the range that was stated.
By their numbers in this assay, from the lowest: compound 2; then compound 4; then compound 1. At a limit, above all of these: compound 3.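

The amine end of the chain can carry more than plain alkyl groups: (carbamoylmethyl)amino in place of dipropylamino restores activity in this assay (an at least 21-fold lower number from compound 3 to compound 4 (1.33 log units; beyond the scatter)). Putting carbamoyl in place of ethyl on the propylamino group costs only a modest amount (a 2.3-fold higher number from compound 2 to compound 4 (0.36 log units; beyond the scatter)), and the (carbamoylmethyl)amino end still gives a modestly lower number than diethylamino (a 2.1-fold lower number from compound 1 to compound 4 (0.33 log units; beyond the scatter)). The value for compound 3 is a limit, so the first of these steps gives only a bound: (the limit of > 50000 nM in this assay, at which 1 of the 4 values shown sits).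

From the compounds shown here alone, whether a primary amine, a carboxylic acid at the chain end or a longer chain would hold this level remains open. With a single carbamoyl example, the contributions of its carbonyl and its nitrogen also cannot be told apart.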